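The source may report more compounds than this note shows. Statements on the series, on what has been measured and on what is new or still open speak of the compounds shown alone.

Among the measured compounds shown here, in an ADME assay on the whole organism (plasma, Mus musculus, strain CD1), read by LC-MS, with a stated time of 24 h (on this read-out lower numbers stand for a smaller free fraction and higher numbers for a larger free fraction), compound 2 `CCC(C(=O)O)c1nn(Cc2cn3cc(OCC4CC4)c(Cl)cc3n2)c2ccccc2c1=O` gives 0.013, the lower of the two numbers so far, and compound 1 `O=C(O)Cc1nn(Cc2cn3cc(OCC4CC4)c(Cl)cc3n2)c2ccccc2c1=O` gives 0.045. Next is compound 3 `C[C@H](C(=O)O)c1nn(Cc2cn3cc(OCC4CC4)c(Cl)cc3n2)c2ccccc2c1=O`, which differs from compound 2 as follows: 1-carboxyethyl in place of 1-carboxypropyl on an aromatic carbon. In words, this is 1-carboxyethyl in place of 1-carboxypropyl on an aromatic carbon, with 1 defined stereocentre. For the measured compounds named here, one measured step bears on this change: a 3.5-fold lower number from compound 1 to compound 2 (0.54 log units; beyond the scatter), for ethyl in place of hydrogen on a saturated chain carbon. The group on compound 3 is intermediate between those of compound 1 and compound 2, so part of that modest step is expected to reverse. A higher number is therefore expected in this assay, possibly not beyond the scatter. The data hold no comparison of a defined stereocentre with its absence. The expected step is a 1.8-fold higher number from compound 2 to compound 3 (0.27 log units; within the scatter). Compound 3 is estimated at 0.024, with an expected range of 0.012 to 0.045.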

Compound 3, unbound fraction: 0.032
Estimate against measurement, compound 3: 1.3-fold (0.12 log units) below; low and high end bracket the measured number.
By their numbers in this assay, from the lowest: compound 2; then compounds 3 and 1 (each within the scatter of the next).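

In this assay, 1-carboxyethyl in place of 1-carboxypropyl gives a 2.5-fold higher number from compound 2 to compound 3 (0.39 log units; beyond the scatter) and so takes back much of the earlier drop. Methyl in place of hydrogen on the saturated chain carbon gives a 1.4-fold lower number from compound 1 to compound 3 (0.15 log units; within the scatter) and stays within the scatter, so among these three compounds the clear fall in free fraction appears only with the ethyl of compound 2, not with methyl. Nothing measured on these compounds gives a cause for either step.

Compound 3 carries a defined stereocentre and compound 2 does not, which leaves open how much of their step belongs to chain length and what the opposite configuration of 1-carboxyethyl would give. Also open, as far as these compounds go, is where a longer chain such as 1-carboxybutyl, or two methyl groups on that same carbon, would fall.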